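The source may report more compounds than this note shows. Statements on the series, on what has been measured and on what is new or still open speak of the compounds shown alone.

Compound 1, `O=C(NCc1ccc(CNS(=O)(=O)c2ccccc2)cc1)c1ccc([N+](=O)[O-])cc1`, in an assay on MDA-MB-231 cells for binding affinity to C-X-C chemokine receptor type 4 (Homo sapiens), read by immunofluorescence and microscopy, with stated times of 10 min and 30 min (a lower number here means that less compound is needed, a higher number that more compound is needed for the effect), gives 100 nM. Among the three measured compounds it stands second highest: compound 2, `Cc1ccc(C(=O)NCc2ccc(CNS(=O)(=O)c3ccc(C)cc3)cc2)cc1`, gives 1000 nM in this assay, while compound 3, `Cc1ccc(S(=O)(=O)NCc2ccc(CNC(=O)c3ccc([N+](=O)[O-])cc3)cc2)cc1`, gives 10 nM. The two measured steps frame compound 1 from both sides: a 10-fold lower number from compound 1 to compound 3 (1.00 log units; beyond the scatter), and a 100-fold lower number from compound 2 to compound 3 (2.00 log units; beyond the scatter).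

Compound 4, `O=C(NCc1ccc(CNS(=O)(=O)c2ccccc2)cc1)c1cccc(Cl)c1`, differs from compound 1 in one place: 3-chlorophenyl in place of 4-nitrophenyl on a carbonyl carbon. Among the compounds with values here, no measured step swaps exactly these two groups. The step that bears most on it is a 100-fold lower number from compound 2 to compound 3 (2.00 log units; beyond the scatter), which shows that putting the nitro group onto that aromatic carbon, in place of methyl, brought a large drop in the number needed. Compound 4 removes that nitro group and brings in a 3-chlorophenyl instead, with no hydrogen-bond acceptors where the nitro group had two. On the strength of that step the number for compound 4 is expected to rise clearly beyond the scatter in this assay, though a chloro group is not a methyl group, so the size is uncertain and the expected step is a 10-fold higher number from compound 1 to compound 4 (1.00 log units; beyond the scatter). The estimate for compound 4 in this assay is 1000 nM, in a range from 200 nM to 5000 nM.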

Compound 4, effective concentration (reported as EC, without a stated level of effect): 1000 nM
Compound 4: the middle estimate sits on the measured number at the digits printed; measured number inside the range.
By their numbers in this assay, from the lowest: compound 3; then compound 1; then compounds 2 and 4 (each within the scatter of the next).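

In this assay, a 10-fold higher number from compound 1 to compound 4 (1.00 log units; beyond the scatter) shows that the group on this carbonyl carbon still governs the number in the core of compound 1, which lacks the methyl on the other aromatic ring. Within the data shown here, until now, a change at this place had been seen only in the methyl-bearing core, in the step between compound 2 and compound 3, so this sensitivity is now seen in both cores. The change from 4-nitrophenyl to 3-chlorophenyl replaces the substituent and alters its printed ring position in one step, and no evidence is available to explain the rise in the number.

The compounds shown do not separate those two parts of the change: 3-nitrophenyl and 4-chlorophenyl on the same carbonyl carbon would be needed to tell them apart. As far as these compounds go, it also remains open whether a nitrile or a carboxylic acid on this ring would keep the number close to that of compound 1, and whether adding a methyl to the other aromatic ring of compound 4 would lower its number as it does from compound 1 to compound 3.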